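A few compounds are considered here, and "the series" means these few. Any claim that something is new, unique, unknown or untested is made for them only; others in the source may bear on it.

Compound 1, `CCC(=O)N1CC[C@H](Oc2ncnc3c2nc(-c2cnc(C)nc2)n3CC)C1`: 2.4 L/kg
Compound 2, `CCn1c(-c2cnc(C)nc2)nc2c(N[C@H]3CCN(C(=O)N4CC(OC)C4)C3)ncnc21`: 4.8 L/kg
Compound 3, `CCC(=O)N1CC[C@H](Nc2ncnc3c2nc(-c2cnc(C)nc2)n3CC)C1`: 3.6 L/kg

These three compounds were measured in an ADME assay (Rattus norvegicus, strain Wistar Han) for pharmacokinetics; a higher number here means that more of the compound sits outside the plasma, a lower number that more of the compound stays in the plasma. Compound 1 gives the lowest of the three numbers, but its gaps to compound 3 and to compound 2 both lie within the usual scatter of repeated measurements, so no real ordering among them can be read from these values. Compound 4, `CCn1c(-c2cnc(C)nc2)nc2c(O[C@H]3CCN(C(=O)[C@H]4C[C@@H](OC)C4)C3)ncnc21`, has not yet been measured. It differs from compound 1 in one place: 3-methoxycyclobutyl in place of ethyl on a carbonyl carbon. For the measured compounds named here, the one measured step that touches the same position is a 1.3-fold lower number from compound 2 to compound 3 (0.12 log units; within the scatter), a change that stayed within the scatter. Compound 1 and compound 3, which differ elsewhere, show values that also sit within the scatter of each other. On this basis the step from compound 1 to compound 4 is expected to be small, estimated as a 1.2-fold higher number from compound 1 to compound 4 (0.07 log units; within the scatter), with a slight rise rather than a fall being the more likely side. Compound 4 is therefore expected to give about 2.8 L/kg in this assay, with a plausible range from 1.5 L/kg to 5.2 L/kg.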

Compound 4, volume of distribution: 2.5 L/kg
The estimate for compound 4 lay 1.1-fold (0.05 log units) above the measured number; measured number inside the range.
By their numbers in this assay, from the lowest: compounds 1, 4, 3 and 2 (each within the scatter of the next).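

In this assay, replacing ethyl with 3-methoxycyclobutyl on this carbonyl carbon gives a 1.0-fold higher number from compound 1 to compound 4 (0.02 log units; within the scatter), even though the group grows from 2 heavy atoms to 6 and brings in a four-membered ring of carbon only, an oxygen and 2 defined stereocentres. The earlier step at this carbonyl carbon, a 1.3-fold lower number from compound 2 to compound 3 (0.12 log units; within the scatter), exchanged 3-methoxyazetidin-1-yl for ethyl, so both steps now available at this place, each with a different ring-bearing group, stay within the scatter, and no compound shown goes against this. No measurement here explains why the number hardly responds to these changes.

All the groups shown at this place carry no net charge, so it remains open whether an amine or a carboxylic acid on this carbonyl carbon would give a step beyond the scatter. Also open is whether a longer chain or the other stereoisomers of 3-methoxycyclobutyl would behave in the same way, since the compounds shown hold only ethyl and two methoxy-bearing rings here.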